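Swapping Pyrazin-2-yl on a Compound Held at a Limit

The source may report more compounds than this note shows. Statements on the series, on what has been measured and on what is new or still open speak of the compounds shown alone.

Compound 1 `O=C(NCCCCc1ccccc1)c1cccc(C2SCC(=O)N2c2cnccn2)c1` gives no exact potency in a functional assay on HOS-TE85 cells (Homo sapiens) for inhibition, read by CCK-8 assay, with a stated time of 72 h; a higher number here means a weaker inhibitor, a lower number a stronger inhibitor. Compound 1 reads > 1000 nM, and this is a limit of the assay rather than a number. Compound 2 `COc1ccccc1N1C(=O)CSC1c1cccc(C(=O)NCCCCn2cncn2)c1` reads > 1000 nM, which is also a limit. For the measured compounds named here, compound 1 therefore has no measured value from which a change can be counted, and no step between measured compounds is available to set its likely size.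

Compound 3 `Cc1cccc(N2C(=O)CSC2c2cccc(C(=O)NCCCCc3ccccc3)c2)c1` differs from compound 1 in one place, with 3-methylphenyl in place of pyrazin-2-yl on an amide-type nitrogen in a ring. The expectation for this change rests on (the limit of > 1000 nM in this assay, at which 2 of the 2 values shown sit), a record that consists of compound 1 and compound 2. No move beyond the scatter is expected in this assay, in either direction. The estimated change is a step that the limit leaves unreadable from compound 1 to compound 3, and a further reading at the limit is the likeliest single outcome. For compound 3 the estimated value is 1500 nM, with an expected range from 400 nM to 6000 nM.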

Compound 3, half-maximal inhibitory concentration: 93.2 nM
Beside the measured number, compound 3's estimate is 16-fold (1.21 log units) above it, outside the stated range (below it).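

In this assay, 3-methylphenyl in place of pyrazin-2-yl on the amide-type nitrogen gives an at least 10-fold lower number from compound 1 to compound 3 (1.03 log units; beyond the scatter), so this position on the shared core can carry a compound clear of the limit with a single change. Compound 1 reads > 1000 nM, which is a limit and not a number, so the step gives only a minimum size for the change. Compound 3 is the first compound here with an exact value, and it shows that the group at this position can decide whether a number is read at all, where the earlier compounds offered only this: the limit of > 1000 nM in this assay, at which 2 of the 3 values shown sit.

The exchange alters two things at once, replacing a ring with two hetero atoms by a ring of carbon only and adding a methyl group, and the compounds shown do not separate the two. From the compounds shown here alone, it remains open whether unsubstituted phenyl, 3-chlorophenyl or pyridin-3-yl on this nitrogen would stay clear of the limit, and how far the methyl group matters.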